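The compounds below may be only part of what the source reports. "The series", "measured", "known", "first", "only" and "open" are said of these compounds alone.

Measured so far:
Compound 1, `Cc1ccc(S(=O)(=O)NCc2cn(C[C@H](O)[C@H]3OC(=O)C(OCc4ccccc4)=C3OCc3ccccc3)nn2)cc1`: 50 nM
Compound 2, `O=C1O[C@H]([C@@H](O)Cn2cc(-c3cc(F)cc(F)c3)nn2)C(OCc2ccccc2)=C1OCc1ccccc1`: > 100000 nM
Compound 3, `O=C1O[C@H]([C@@H](O)Cn2cc(CNS(=O)(=O)c3ccc(F)cc3)nn2)C(OCc2ccccc2)=C1OCc1ccccc1`: 30 nM

In an ADME assay on HFF cells (Homo sapiens) for cytotoxicity, read by MTT assay, with a stated time of 72 h (on this read-out higher numbers stand for weaker inhibition and lower numbers for stronger inhibition), compound 3 gives 30 nM, the lowest of the two numbers shown. Compound 1 stands nearest, and the difference a 1.7-fold lower number from compound 1 to compound 3 (0.22 log units; within the scatter) is too small to rank the two. Compound 2 gives no number in this assay, only the limit > 100000 nM.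

Compound 4, `COc1ccc(-c2cn(C[C@H](O)[C@H]3OC(=O)C(OCc4ccccc4)=C3OCc3ccccc3)nn2)cc1`, is not yet measured. Relative to compound 3 the change is 4-methoxyphenyl in place of (((4-fluorophenyl)sulfonyl)amino)methyl on an aromatic carbon. Among the compounds with values here, two measured steps bear on this: replacing the sulfonamide-bearing arm by an aryl ring gave an at least 2000-fold higher number from compound 1 to compound 2 (3.30 log units; beyond the scatter), and the reverse swap gave an at least 3300-fold lower number from compound 2 to compound 3 (3.52 log units; beyond the scatter). Compound 4 makes the same kind of swap, an aryl ring in place of the sulfonamide-bearing arm, so a large rise in this assay is expected, most likely reaching (the limit of > 100000 nM in this assay, at which 1 of the 3 values shown sits). The expected step is therefore a 3300-fold higher number from compound 3 to compound 4 (3.52 log units; beyond the scatter). For compound 4 the estimate in this assay is 100000 nM, within 5000 nM to 200000 nM.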

Compound 4, half-maximal inhibitory concentration: < 10 nM
Compound 4 ended at the assay's limit; the forecaster's own chance of this, stated with the estimate: 70%; middle value at least 10000-fold (4.00 log units) from the limit.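

In this assay compound 4 reaches a limit of the assay, not a number: the limit of < 10 nM in this assay, at which 1 of the 4 values shown sits.

Replacing the sulfonamide-bearing arm with an aryl ring on this aromatic carbon therefore need not raise the number: 4-methoxyphenyl gives an at least 3.0-fold lower number from compound 3 to compound 4 (0.47 log units; beyond the scatter) and an at least 5.0-fold lower number from compound 1 to compound 4 (0.69 log units; beyond the scatter). Between the two aryl groups themselves the gap is an at least 10000-fold lower number from compound 2 to compound 4 (4.00 log units; beyond the scatter), so the large rise seen earlier goes with 3,5-difluorophenyl in particular, not with the loss of the arm in general.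

The compounds shown do not tell whether the methoxy group, the two fluorines or their places on the ring set this gap, and how far compound 4 lies past its limit stays unknown. An unsubstituted phenyl ring, or a phenyl ring carrying an amine or a carboxylic acid, on this same carbon would be a further test of the aryl series.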